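The source may hold more compounds than are shown below. What is called first, only, known or untested is meant among the compounds shown, and "the series" means these compounds.

Compound 1 `C=C(C)C(=O)c1ccc(OCCCN2CCN(C(=O)OCC)CC2)cc1` and compound 2 `CCOC(=O)N1CCN(CCCOc2ccc(C(=O)c3cccc(F)c3F)cc2)CC1` share a core and differ only in the group carried on a carbonyl carbon. In an assay on isolated protein for binding affinity to histamine H2 receptor (Homo sapiens) (on this read-out lower numbers stand for stronger inhibition and higher numbers for weaker inhibition), compound 1 gives 22400 nM, and in this assay compound 2 gives 17400 nM. The step of a 1.3-fold lower number from compound 1 to compound 2 (0.11 log units; within the scatter) is too small to mean anything, so compound 2 sits within the scatter of compound 1 and neither can be ranked above the other; compound 2 simply has one of two numbers that are, for practical purposes, the same.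

Compound 3 `CCOC(=O)N1CCN(CCCOc2ccc(C(=O)/C=C/c3ccc(OC)cc3)cc2)CC1` is the next member. The change is 2-(4-methoxyphenyl)ethenyl in place of 2,3-difluorophenyl on a carbonyl carbon. Going by the values given here, only one measured step bears on it, a 1.3-fold lower number from compound 1 to compound 2 (0.11 log units; within the scatter), which swapped the group on the same carbonyl carbon and left the number inside the scatter. That single example gives no reason to expect a large move in this assay in either direction, so the expected step of a 1.2-fold lower number from compound 2 to compound 3 (0.06 log units; within the scatter) is modest. On that basis compound 3 is estimated to give 15000 nM in this assay, with a range expected from 5000 nM to 50000 nM.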

Compound 3, inhibition constant: 6760 nM
Compound 3: middle estimate off by 2.2-fold (0.35 log units), on the high side; the range from low to high includes it.
By their numbers in this assay, from the lowest: compound 3; then compounds 2 and 1 (each within the scatter of the next).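

Going by these compounds alone, the group on the carbonyl carbon can shift the number in this assay beyond the scatter: the change gives a 2.6-fold lower number from compound 2 to compound 3 (0.41 log units; beyond the scatter) and, against the other earlier compound, a 3.3-fold lower number from compound 1 to compound 3 (0.52 log units; beyond the scatter), whereas the only earlier swap, a 1.3-fold lower number from compound 1 to compound 2 (0.11 log units; within the scatter), showed no readable change. The group that enters, 2-(4-methoxyphenyl)ethenyl, differs from 2,3-difluorophenyl in several counted ways at once, with more heavy atoms, a double bond outside the aromatic ring and a hydrogen-bond acceptor, so these steps cannot assign the lower number to any one of those features. Nothing available here explains why this group goes with the lower number.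

Still open, going by these compounds, is whether the ethenyl link or the methoxy group matters more, a question that a plain 2-phenylethenyl group, or a 4-methoxyphenyl group set directly on the carbonyl carbon, could help to separate. Also open, on these data alone, is how the number would respond if an amine or a carboxylic acid took the place of the methoxy group, or if a longer chain replaced the ethenyl link.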